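The source may report more compounds than this note shows. Statements on the series, on what has been measured and on what is new or still open speak of the compounds shown alone.

- Compound 1 `CCN(CCNC(=O)c1cc(Cl)c(N)cc1OC)Cc1ccoc1`: 3 mg/kg
- Compound 2 `COc1cc(N)c(Cl)cc1C(=O)NCCN(C)CC1CCCCC1`: 3 mg/kg
- Compound 3 `CCN(CCNC(=O)c1cc(Cl)c(N)cc1OC)Cc1cccc(OC)c1`: 1 mg/kg

In a functional assay on the whole organism with Rattus norvegicus as the target (on this read-out lower numbers stand for an effect already at smaller amounts and higher numbers for an effect only at larger amounts of compound), compound 1 gives 3 mg/kg, level with compound 2, while compound 3 sits lower. The next candidate, compound 4 `CCN(CCNC(=O)c1cc(Cl)c(N)cc1OC)Cc1ccc(OC)cc1`, differs from compound 1 as follows: 4-methoxyphenyl in place of furan-3-yl on a saturated chain carbon bound to an amine nitrogen. Among the measured compounds shown here, one measured step bears on this change: a 3.0-fold lower number from compound 1 to compound 3 (0.48 log units; beyond the scatter), where 3-methoxyphenyl takes the place of furan-3-yl at the same spot. For the measured compounds named here, compound 4 carries 4-methoxyphenyl there instead, and no measured pair compares these two groups directly. A step in the same direction is therefore expected, but with less confidence and perhaps of smaller size. The estimated step is a 2.0-fold lower number from compound 1 to compound 4 (0.30 log units; within the scatter). For compound 4, the expected value is 1.5 mg/kg, within an estimated range of 0.5 mg/kg to 4 mg/kg.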

Compound 4, dose for half-maximal effect: 0.2 mg/kg
Compound 4: the middle estimate sits 7.5-fold (0.88 log units) above what was measured; measured number outside the range, below it.
By their numbers in this assay, from the lowest: compound 4; then compound 3; then compounds 1 and 2 (each within the scatter of the next).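

The position of the methoxy group on the phenyl ring matters at this spot: 3-methoxyphenyl and 4-methoxyphenyl are not interchangeable (a 5.0-fold lower number from compound 3 to compound 4 (0.70 log units; beyond the scatter)). Measured against furan-3-yl, 4-methoxyphenyl gives a large step (a 15-fold lower number from compound 1 to compound 4 (1.18 log units; beyond the scatter)), so a group at this spot can shift the effective dose substantially. No measurement here explains why. The compounds shown leave open whether an unsubstituted phenyl group would keep this gain, and so how much of it depends on the methoxy group. They also leave open whether 4-hydroxyphenyl or 4-chlorophenyl would serve equally well.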